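Biphenyl in place of trifluoromethylphenoxy: stability outlook

The source may report more compounds than this note shows. Statements on the series, on what has been measured and on what is new or still open speak of the compounds shown alone.

The two measured compounds were examined in an ADME assay on S9 fraction from liver (Rattus norvegicus) for metabolic stability, read by LC-MS, using NADPH, with a stated time of 30 min; on this read-out higher numbers stand for a more stable compound and lower numbers for a less stable compound. Compound 1, with the structure `CC(Oc1ccc(-c2ccccc2)cc1)C(=O)Cn1nnc(-c2ccc(Cl)cc2)n1`, gives 18% in this assay. Compound 2, with the structure `COC(=O)c1ccc(-c2nnn(CC(=O)C(C)Oc3ccc(Oc4ccc(C(F)(F)F)cc4)cc3)n2)cc1`, gives 15% in this assay. Compound 2 stands lowest of the two numbers, but its nearest neighbour is compound 1 at a distance within the usual scatter, so the two values cannot be told apart.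

Compound 3, with the structure `COC(=O)c1ccc(-c2nnn(CC(=O)C(C)Oc3ccc(-c4ccccc4)cc3)n2)cc1`, has not yet been measured in this assay. It differs from compound 2 in one place: phenyl in place of 4-(trifluoromethyl)phenoxy on an aromatic carbon. Within the data shown here, no step between measured compounds covers this change, so the expected size of the step has to rest on the two values shown. Both lie close together at the low end of the scale, and compound 1 also carries a phenyl on the shared core. A step from compound 2 to compound 3 of a number 1 percentage points higher from compound 2 to compound 3 (within the scatter) is therefore expected, which is none beyond the scatter. For compound 3 the expected value in this assay is 16%, with a range from 6% to 30%, because compound 1 gives 18%.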

Compound 3, percent of the compound remaining in the Rattus norvegicus assay: 21%
Beside the measured number, compound 3's estimate is 5 percentage points below it; measured number inside the range.
By their numbers in the Rattus norvegicus assay, from the lowest: compounds 2, 1 and 3 (each within the scatter of the next).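

In the Rattus norvegicus assay, phenyl in place of 4-(trifluoromethyl)phenoxy, on an aromatic carbon para to a large group, comes with a number 6 percentage points higher from compound 2 to compound 3 (within the scatter), so removing the outer ring and its oxygen and trifluoromethyl atoms, and going from 11 heavy atoms to 6, leaves no change that can be told from scatter. The second single change, methoxycarbonyl in place of chloro on an aromatic carbon, also stays inside the scatter, with a number 3 percentage points higher from compound 1 to compound 3 (within the scatter), so neither of the two places shown moves this number clearly. In a physicochemical assay for lipophilicity, read by HPLC, tested at 5 mM (a lower number here means a more polar compound, a higher number a more lipophilic compound), compound 2 gives 6.2 and compound 3 gives 5.4. Stability in the Rattus norvegicus assay thus stayed within the scatter even though the same replacement of 4-(trifluoromethyl)phenoxy by phenyl came with a clearly lower partition coefficient in the physicochemical assay: the measured partition coefficient of compound 2, 6.2, and of compound 3, 5.4, a number 0.80 log units lower (beyond the scatter)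

As far as these compounds go, whether any group at this position can lift the stability number clear of the scatter stays open, for instance an amine or a carboxylic acid in place of phenyl. The compounds shown also do not tell which part of the shared structure sets the low numbers in the Rattus norvegicus assay.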